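Amide Replacement on a Weak Spiro Core

The source may hold more compounds than are shown below. What is called first, only, known or untested is meant among the compounds shown, and "the series" means these compounds.

Measured compounds:
- compound 1, `CC(C)(C)c1ccc(C(=O)N2CCC3(CC2)C(=O)N(CC(=O)N2CCCC(C(N)=O)C2)CN3c2ccccc2)cc1`: 16900 nM
- compound 2, `NC(=O)C1CCCN(C(=O)CN2CN(c3ccccc3)C3(CCN(C(=O)c4ccc(C5CCCCC5)cc4)CC3)C2=O)C1`: 3100 nM

In an assay on HEK293 cells for displacement of a labelled ligand from NPC1-like intracellular cholesterol transporter 1 (Homo sapiens) (on this read-out higher numbers stand for weaker inhibition and lower numbers for stronger inhibition), compound 1 gives 16900 nM, the highest of the two numbers; its nearest neighbour is compound 2, and the step of a 5.5-fold lower number from compound 1 to compound 2 (0.74 log units; beyond the scatter) comes from a change at the aromatic carbon far from the amide end. Compound 3, `CC(C)(C)c1ccc(C(=O)N2CCC3(CC2)C(=O)N(CC(=O)NCCCNS(C)(=O)=O)CN3c2ccccc2)cc1`, is not yet measured. It differs from compound 1 only at the other end: (3-(methanesulfonamido)propyl)amino in place of 3-carbamoylpiperidin-1-yl on a carbonyl carbon. Among the compounds with values here, no measured step touches this part of the molecule, so the only comparison available is unrelated to the change and gives no direction. The account therefore expects for compound 3 a step of a 1.0-fold higher number from compound 1 to compound 3 (0.00 log units; within the scatter), that is no step beyond the scatter, with a wide range. Compound 3 is estimated at 17000 nM, between 5000 nM and 60000 nM in this assay.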

Compound 3, half-maximal inhibitory concentration: 10400 nM
Estimate against measurement, compound 3: 1.6-fold (0.21 log units) above, within the range that was stated.
By their numbers in this assay, from the lowest: compound 2; then compounds 3 and 1 (each within the scatter of the next).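

The amide end of the molecule now has its first measured step in this assay, and the step of a 1.6-fold lower number from compound 1 to compound 3 (0.21 log units; within the scatter) shows that the open (3-(methanesulfonamido)propyl)amino chain and the ring-bearing 3-carbamoylpiperidin-1-yl group cannot be told apart on this read-out. On the core of compound 1, then, this position tolerates the loss of the six-membered ring and the entry of a sulfonamide without a change beyond the scatter. Nothing available accounts for this result beyond the numbers themselves.

Going by these compounds, it remains open whether a carboxylic acid, a primary amine or a longer chain at this position would move the number beyond the scatter. On these data alone, it is also open whether cyclohexyl in place of tert-butyl would give a comparable step with the (3-(methanesulfonamido)propyl)amino group in place.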